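The source may report more compounds than this note shows. Statements on the series, on what has been measured and on what is new or still open speak of the compounds shown alone.

Compound 1 `O=C(Nc1cccc(Cl)c1)c1cccc(Br)c1` joins two aromatic rings through an amide. In an assay on isolated protein for inhibition of thiosulfate sulfurtransferase (Homo sapiens), with a stated time of 60 min, in the absence of a further agent (a higher number here means a weaker inhibitor, a lower number a stronger inhibitor), compound 1 gives > 100000 nM, which is a limit of the assay and not a number. Compound 2 `O=C(Nc1cccc(Cl)c1)c1cccc(Br)c1O` differs from compound 1 by hydroxy in place of hydrogen on an aromatic carbon. In this assay compound 2 gives > 100000 nM, again a limit rather than a number. The step that the two limits leave unreadable from compound 1 to compound 2 therefore offers nothing to read. Compound 3 `O=C(Nc1ccc(Sc2nc3ccccc3s2)cc1)c1cccc(Br)c1` is built on a different core, and the difference between the cores of compound 1 and compound 3 is not broken down here. In this assay compound 3 gives > 100000 nM, once more a limit of the assay. Going by the values given here, the only evidence running across these measurements is the limit of > 100000 nM in this assay, at which 3 of the 3 values shown sit.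

Compound 4 `O=C(Nc1ccc(Sc2nc3ccccc3s2)cc1)c1cc(Br)ccc1O` has not yet been measured. It differs from compound 3 by hydroxy in place of hydrogen on an aromatic carbon. This is the same kind of change as that from compound 1 to compound 2, though not the same: in compound 2 the hydroxy enters ortho to a bromo group and ortho to a large group, whereas in compound 4 it enters ortho to a large group and para to a bromo group. The expected step of a number no higher from compound 3 to compound 4 (the limit leaves the size open) rests almost entirely on (the limit of > 100000 nM in this assay, at which 3 of the 3 values shown sit). Compound 4 is accordingly expected to give 100000 nM in this assay. For compound 4 the estimated span runs from 30000 nM to 300000 nM, and the measurement is most likely to come back as a limit again.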

Compound 4, half-maximal inhibitory concentration: > 100000 nM
Compound 4 ended at the assay's limit (the forecaster's own chance of this, stated with the estimate: 80%); the middle value lies on the limit itself.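

In this assay compound 4 gives > 100000 nM as a limit of the assay and not a number. Compound 3 also stands at a limit, so no step can be read between compound 3 and compound 4. The compounds shown leave open what change, if any, would bring a value that can be read as a number, and all that runs across them is this: the limit of > 100000 nM in this assay, at which 4 of the 4 values shown sit.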